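Shortening the Acyl Chain: From tert-Butyl to Propyl

A few compounds are considered here, and "the series" means these few. Any claim that something is new, unique, unknown or untested is made for them only; others in the source may bear on it.

Compound 1 `CC(=O)N1CCN(c2nnc3nncn3n2)CC1` gives 14700 nM in a functional assay on HL-60 cells (Homo sapiens) for inhibition, read by MTT assay, with a stated time of 72 h; on this read-out higher numbers stand for weaker inhibition and lower numbers for stronger inhibition.
Compound 2 `CC(C)C(=O)N1CCN(c2nnc3nncn3n2)CC1` gives 1610 nM in this assay.
Compound 3 `CC(C)(C)C(=O)N1CCN(c2nnc3nncn3n2)CC1` gives 1380 nM in this assay.

Compound 3 holds the lowest number of the three, but its gap to compound 2 sits within the scatter, as a 1.2-fold lower number from compound 2 to compound 3 (0.07 log units; within the scatter) shows; only compound 1 stands clearly apart, with an 11-fold lower number from compound 1 to compound 3 (1.03 log units; beyond the scatter). Compound 4 `CCCC(=O)N1CCN(c2nnc3nncn3n2)CC1` differs from compound 3 in one place: propyl in place of tert-butyl on a carbonyl carbon. Among the measured compounds shown here, two measured steps bear on this, a 9.1-fold lower number from compound 1 to compound 2 (0.96 log units; beyond the scatter) and an 11-fold lower number from compound 1 to compound 3 (1.03 log units; beyond the scatter), both showing that replacing methyl with a bulkier group brought a much lower number, while a 1.2-fold lower number from compound 2 to compound 3 (0.07 log units; within the scatter) separates isopropyl and tert-butyl hardly at all. Propyl carries more carbons than methyl, so compound 4 is expected to fall between compound 1 and compound 3, nearer compound 3, with an expected step of a 1.8-fold higher number from compound 3 to compound 4 (0.26 log units; within the scatter). The estimate for compound 4 is 2500 nM, within a range from 900 nM to 7000 nM.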

Compound 4, half-maximal inhibitory concentration: 9840 nM
For compound 4 the middle estimate is 3.9-fold (0.60 log units) below the measured one; measured number outside the range, above it.
By their numbers in this assay, from the lowest: compounds 3 and 2 (each within the scatter of the next); then compounds 4 and 1 (each within the scatter of the next).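

At this position, the shape of the group on the carbonyl carbon matters, not just its being larger than methyl: the straight propyl chain of compound 4 loses the gain held by the branched groups (a 7.1-fold higher number from compound 3 to compound 4 (0.85 log units; beyond the scatter); a 6.1-fold higher number from compound 2 to compound 4 (0.79 log units; beyond the scatter)). Compound 4 cannot be told apart from the methyl compound (a 1.5-fold lower number from compound 1 to compound 4 (0.17 log units; within the scatter)), so this propyl chain brings no clear gain over methyl.

On these data alone, how a longer chain such as butyl or a ring such as cyclopropyl would read on this carbonyl carbon remains open. Nothing available explains why propyl parts from isopropyl and tert-butyl.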